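Amide series: from compound 1 to compound 4

This account rests on a few compounds, and the source may have more. Where it says the series, first, only, none or still open, it means among the compounds named here.

Compound 1 `CS(=O)(=O)Nc1ccc(CNC(=O)c2ccc(C3(C(F)(F)F)CC3)cc2)c(Cl)c1` gives 540 nM in an assay on HeLa cells for agonist activity at Bile acid receptor (Homo sapiens), read by a luciferase reporter, with a stated time of 24 h; on this read-out higher numbers stand for an effect only at larger amounts of compound and lower numbers for an effect already at smaller amounts.
Compound 2 `CC(C)Oc1ccc(C(=O)NCc2ccc(NS(C)(=O)=O)cc2Cl)cc1` gives 400 nM in this assay.
Compound 3 `CC(F)(F)c1ccc(C(=O)NCc2ccc(NS(C)(=O)=O)cc2Cl)cc1` gives 1200 nM in this assay.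

Among these three numbers compound 1 stands second highest: compound 2 is the nearest, a 1.4-fold lower number from compound 1 to compound 2 (0.13 log units; within the scatter), and compound 3 the furthest, a 2.2-fold higher number from compound 1 to compound 3 (0.35 log units; beyond the scatter). Compound 4 `CS(=O)(=O)Nc1ccc(CNC(=O)c2ccc(CC(F)(F)F)cc2)c(Cl)c1` is not yet measured; against compound 1 the change is 2,2,2-trifluoroethyl in place of 1-(trifluoromethyl)cyclopropyl on an aromatic carbon. The step that bears most on it is a 2.2-fold higher number from compound 1 to compound 3 (0.35 log units; beyond the scatter), where a group without a ring likewise replaced the same cyclopropyl group; the related step of a 3.0-fold higher number from compound 2 to compound 3 (0.48 log units; beyond the scatter) runs the same way. A modest rise in the number is therefore expected for compound 4, roughly a 1.8-fold higher number from compound 1 to compound 4 (0.25 log units; within the scatter). Compound 4 is estimated at 950 nM, within a range from 400 nM to 2500 nM.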

Compound 4, half-maximal effective concentration: 4000 nM
Beside the measured number, compound 4's estimate is 4.2-fold (0.62 log units) below it; measured number outside the range, above it.
By their numbers in this assay, from the lowest: compounds 2 and 1 (each within the scatter of the next); then compound 3; then compound 4.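

Replacing 1-(trifluoromethyl)cyclopropyl with 2,2,2-trifluoroethyl (a 7.4-fold higher number from compound 1 to compound 4 (0.87 log units; beyond the scatter)) moves the number much further than the earlier change to 1,1-difluoroethyl, so ring-free groups at this position are not interchangeable. The two ring-free fluorinated groups also separate from each other (a 3.3-fold higher number from compound 3 to compound 4 (0.52 log units; beyond the scatter)), and the gap from isopropoxy is wider still (a 10-fold higher number from compound 2 to compound 4 (1.00 log units; beyond the scatter)), leaving compound 4 with the highest number of the four. Nothing available here accounts for these steps.

Going by these compounds, how plain cyclopropyl, ethyl or tert-butyl would stand at this position remains open. So does whether the ring or the fluorine atoms matter more here.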